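A few compounds are considered here, and "the series" means these few. Any claim that something is new, unique, unknown or untested is made for them only; others in the source may bear on it.

Working notes on the series. In a functional assay on the whole organism (strain Swiss albino) with Mus musculus as the target, in the maximal electroshock model, with a stated time of 2 h (a higher number here means that more compound is needed for the effect, a lower number that less compound is needed), compound 2 `O=C1NC(=O)C(c2ccccc2Cl)CC1c1ccccc1Cl` gives 25.5 mg/kg, the only plain number shown for the set. Compound 1 `O=C1C(c2ccccc2)CC(c2ccccc2)C(=O)N1c1cccc(Cl)c1`, which carries a 3-chlorophenyl on the amide-type nitrogen in the ring, gives only a limit in this assay, > 100 mg/kg; that limit is the limit of > 100 mg/kg in this assay, at which 1 of the 2 values shown sits. Compound 3 `O=C1C(c2ccccc2Cl)CC(c2ccccc2Cl)C(=O)N1c1cccc(Cl)c1`, still to be tested, differs from compound 2 in one place: 3-chlorophenyl in place of hydrogen on an amide-type nitrogen in a ring. Within the data shown here, no step between two measured compounds is available for this change. The pointer is compound 1, whose the limit of > 100 mg/kg in this assay, at which 1 of the 2 values shown sits, sits on the same nitrogen substitution, so the expected step from compound 2 to compound 3 is toward more compound being needed, larger than the usual scatter, with a real chance that only a limit comes back. On that basis compound 3 is estimated at 80 mg/kg in this assay, within 35 mg/kg to 160 mg/kg, an expected change of a 3.1-fold higher number from compound 2 to compound 3 (0.50 log units; beyond the scatter).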

Compound 3, dose for half-maximal effect: 60.2 mg/kg
For compound 3 the middle estimate is 1.3-fold (0.12 log units) above the measured one; the measured number falls inside the stated range.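

Among these compounds, the first direct reading of 3-chlorophenyl in place of hydrogen on the amide-type nitrogen in a ring in this assay is a 2.4-fold higher number from compound 2 to compound 3 (0.37 log units; beyond the scatter), so replacing that hydrogen raises the dose needed. The change does not abolish the effect, since compound 3 still returns a plain number and not a limit. Compound 1, which carries the same group on that nitrogen, stands only as a limit and not as a number: the limit of > 100 mg/kg in this assay, at which 1 of the 3 values shown sits.

From the compounds shown here alone, compound 1 differs from compound 3 in more than one place, so no step can be read between them, and the part played by the 2-chlorophenyl groups stays open. Also open, going by these compounds, is how a methyl group or a 2-aminoethyl chain on that nitrogen would compare with compound 2.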